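Dimethoxyphenyl amide in a nitrobenzofurazan thioether series

A few compounds are considered here, and "the series" means these few. Any claim that something is new, unique, unknown or untested is made for them only; others in the source may bear on it.

Compound 1 `O=C(CCC(=O)OCCCCCCSc1ccc([N+](=O)[O-])c2nonc12)Nc1ccccc1` and compound 2 `O=C(CCC(=O)OCCCCCCSc1ccc([N+](=O)[O-])c2nonc12)Nc1ccc(Br)cc1` share a long chain ending in an amide on an aromatic ring. In a functional assay on HOS cells (Homo sapiens) for inhibition, read by MTT assay, with a stated time of 72 h (a lower number here means a stronger inhibitor, a higher number a weaker inhibitor), compound 1 gives 2120 nM, and compound 2 gives 2160 nM. The step of a 1.0-fold higher number from compound 1 to compound 2 (0.01 log units; within the scatter) shows that adding a bromine on the ring did not move the number, and compound 2 and compound 1 therefore give numbers within the scatter of each other. Compound 3 `COc1ccc(NC(=O)CCC(=O)OCCCCCCSc2ccc([N+](=O)[O-])c3nonc23)cc1OC` carries the change (3,4-dimethoxyphenyl in place of 4-bromophenyl on an amide-type nitrogen). For the measured compounds named here, the only measured step at this ring, a 1.0-fold higher number from compound 1 to compound 2 (0.01 log units; within the scatter), is within the scatter, so no change beyond the scatter is expected for this further change; this is an expectation from one step only. The step of a 1.0-fold higher number from compound 2 to compound 3 (0.01 log units; within the scatter) is the estimated size. Compound 3 is expected to give about 2200 nM, with a range from 1000 nM to 4800 nM.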

Compound 3, half-maximal inhibitory concentration: 1390 nM
Compound 3: middle estimate off by 1.6-fold (0.20 log units), on the high side; the measured number falls inside the stated range.
By their numbers in this assay, from the lowest: compounds 3, 1 and 2 (each within the scatter of the next).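

With a 1.6-fold lower number from compound 2 to compound 3 (0.19 log units; within the scatter) and a 1.5-fold lower number from compound 1 to compound 3 (0.18 log units; within the scatter), both steps in this assay stay within the scatter, so phenyl, 4-bromophenyl and 3,4-dimethoxyphenyl on this amide-type nitrogen cannot be told apart. For the compounds shown here, the earlier step changed only a single bromo on the ring, whereas this change replaces the whole 4-bromophenyl group with one carrying two methoxy groups and hydrogen-bond acceptors, and the result still cannot be separated from the other two compounds. Nothing measured here bears on the reason for this result.

From the compounds shown here alone, it remains open whether an amine or a carboxylic acid on this ring, or a cyclohexyl group in place of the ring, would move the number beyond the scatter. Going by these compounds, the effect of a longer chain between the amide and the core also remains open.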